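Lengthening the Side Chain on a Shared Core

The source may hold more compounds than are shown below. What is called first, only, known or untested is meant among the compounds shown, and "the series" means these compounds.

Compound 1 `CCCCCCCCCCOC1=C(O)OC(C(O)CO)C1=O` gives 13000 nM in a functional assay (brain) for inhibition, with Rattus norvegicus as the target; on this read-out lower numbers stand for stronger inhibition and higher numbers for weaker inhibition.
Compound 2 `CCCCCCCCCCCCCOC1=C(O)OC(C(O)CO)C1=O` gives 7400 nM in this assay.
Compound 3 `CCCCCCCCCCCCCCCCCOC1=C(O)OC(C(O)CO)C1=O` gives 11000 nM in this assay.

All three numbers lie within the usual scatter of one another: a 1.8-fold lower number from compound 1 to compound 2 (0.24 log units; within the scatter), a 1.2-fold lower number from compound 1 to compound 3 (0.07 log units; within the scatter) and a 1.5-fold higher number from compound 2 to compound 3 (0.17 log units; within the scatter). Compound 4 `CCCCCCCCCCCCCCCCCCCCOC1=C(O)OC(C(O)CO)C1=O` has not been measured. It differs from compound 3 by propyl in place of hydrogen on a saturated chain carbon, ten or more bonds along the chain from an oxygen on an unsaturated carbon. The same change is made from compound 1 to compound 2, where it gave a 1.8-fold lower number from compound 1 to compound 2 (0.24 log units; within the scatter). The cores of compound 1 and compound 3 themselves differ by heptyl in place of hydrogen on a saturated chain carbon, ten or more bonds along the chain from an oxygen on an unsaturated carbon. For compound 4 a step of about a 1.1-fold higher number from compound 3 to compound 4 (0.04 log units; within the scatter) in this assay is expected, close to the earlier one, because a 1.8-fold lower number from compound 1 to compound 2 (0.24 log units; within the scatter) stayed within the scatter. Compound 4 is therefore estimated at 12000 nM, with a likely range from 5000 nM to 30000 nM.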

Compound 4, half-maximal inhibitory concentration: 4700 nM
The estimate for compound 4 lay 2.6-fold (0.41 log units) above the measured number, outside the stated range (below it).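

In this assay, propyl in place of hydrogen gives a 2.3-fold lower number from compound 3 to compound 4 (0.37 log units; beyond the scatter), and this agrees with the same change made earlier: the same change on two cores in this assay, a 1.8-fold lower number (0.24 log units; within the scatter) from compound 1 to compound 2 and a 2.3-fold lower number (0.37 log units; beyond the scatter) from compound 3 to compound 4, 1.3-fold (0.12 log units) apart, within the scatter of two such steps Heptyl in place of hydrogen gives a 1.6-fold lower number from compound 2 to compound 4 (0.20 log units; within the scatter), and this also agrees with its earlier counterpart: the same change on two cores in this assay, a 1.2-fold lower number (0.07 log units; within the scatter) from compound 1 to compound 3 and a 1.6-fold lower number (0.20 log units; within the scatter) from compound 2 to compound 4, 1.3-fold (0.12 log units) apart, within the scatter of two such steps With decyl in place of hydrogen there is a 2.8-fold lower number from compound 1 to compound 4 (0.44 log units; beyond the scatter), so the full set of chains does span a modest difference, but these agreements rest on one pair of steps per change, all on a single shared core, and do not show that a change will carry over to any other core.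

The compounds shown leave open whether a still longer chain would continue this trend. They also leave open how a chain ending in an amine or a carboxylic acid would behave.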